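Cyano in place of ethoxycarbonyl on a shared core

The source may hold more compounds than are shown below. What is called first, only, known or untested is meant among the compounds shown, and "the series" means these compounds.

Measured so far:
- compound 1 `CCOC(=O)c1nc2ccccn2c1[N+](=O)[O-]` (0.963)
- compound 2 `CCOC(=O)c1nc2cccc(C)n2c1[N+](=O)[O-]` (1.3)

Going by the values given here, only two compounds have numbers so far in a physicochemical assay for lipophilicity, measured as octanol-water partition; a lower number here means a more polar compound, a higher number a more lipophilic compound. Compound 1 stands lowest of the two (0.963), and its nearest neighbour is compound 2 (1.3). Compound 3 `N#Cc1nc2ccccn2c1[N+](=O)[O-]` has not yet been measured. It differs from compound 1 by having cyano in place of ethoxycarbonyl on an aromatic carbon next to the ring atom that bears a nitro group.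

Just one measured step bears on this change, and only loosely. The data show a number 0.34 log units higher from compound 1 to compound 2 (beyond the scatter) with methyl in place of hydrogen on an aromatic carbon, a modest step that adds to the molecule. Among the compounds with values here, the new change instead brings in a smaller group than the one that leaves, and no measured step covers either group. A larger step in the opposite direction in this assay is therefore expected, and the estimate is a number 0.66 log units lower from compound 1 to compound 3 (beyond the scatter) (a wide one, resting on so little). Compound 3 is estimated at 0.3 (expected range -0.2 to 0.8).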

Compound 3, partition coefficient: 0.692
Compound 3: middle estimate off by 0.39 log units, on the low side; low and high end bracket the measured number.
By their numbers in this assay, from the lowest: compounds 3 and 1 (each within the scatter of the next); then compound 2.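

In this assay, cyano in place of ethoxycarbonyl on an aromatic carbon next to the ring atom that bears a nitro group gives a number 0.27 log units lower from compound 1 to compound 3 (within the scatter) and so leaves compound 1 and compound 3 not distinguishable by this read-out. The exchange takes 5 heavy atoms down to 2 and 2 hydrogen-bond acceptors down to 1, so at this position a change of that size in the counted atoms does not carry the number beyond the scatter. Of the two steps now available, only the methyl change, a number 0.34 log units higher from compound 1 to compound 2 (beyond the scatter), lies beyond the scatter, and no measurement shown accounts for the behaviour of either step.

The compounds shown leave open how this position responds to groups of another kind, such as a carboxylic acid, a primary amide or an ester with a longer chain, since ethoxycarbonyl and cyano are the only two groups seen there. They also leave open whether cyano in place of ethoxycarbonyl gives a comparable result on the methyl-bearing core of compound 2, where that exchange has no number to compare.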